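Swapping a Methyl for a Fluoro: Compound 1 to Compound 4

This account rests on a few compounds, and the source may have more. Where it says the series, first, only, none or still open, it means among the compounds named here.

Three compounds have so far been measured in a functional assay on the whole organism with Mus musculus as the target, in the hot plate test; a lower number here means that less compound is needed, a higher number that more compound is needed for the effect:

Compound 1 `Cc1ccc(C(=O)OC2CCN(C)CC2)cc1`, 18.2 mg/kg in this assay
Compound 2 `Cc1cccc(C)c1C(=O)OC1CCN(C)CC1`, 15.2 mg/kg in this assay
Compound 3 `CCOC(=O)[C@@H]1CN(C)CC[C@@H]1OC(=O)c1ccc(OC)c(OC)c1`, 4 mg/kg in this assay

Compound 1 holds the highest of the three numbers. Its nearest neighbour in this assay is compound 2, whose number lies within the scatter of repeated measurements, so the two cannot be ordered. Compound 3 stands furthest away, with a number lower than that of compound 1 by more than the scatter allows.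

Compound 4 `CN1CCC(OC(=O)c2ccc(F)cc2)CC1` is the next compound to be tested. It differs from compound 1 by fluoro in place of methyl on an aromatic carbon. Within the data shown here, no pair among the measured compounds shares this change, so there is no measured step to lean on. What the measured compounds do show is that a small change of the substituents on the aromatic ring, as between compound 1 and compound 2, left the number within the scatter, whereas the larger change to compound 3 moved it beyond.

On this basis the step from compound 1 to compound 4 is expected to be small, a 1.2-fold lower number from compound 1 to compound 4 (0.08 log units; within the scatter), and not to reach beyond the scatter in either direction. Compound 4 is accordingly estimated at 15 mg/kg in this assay, with a range from 6 mg/kg to 40 mg/kg.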

Compound 4, dose for half-maximal effect: 11.5 mg/kg
Estimate against measurement, compound 4: 1.3-fold (0.12 log units) above; the measured number falls inside the stated range.
By their numbers in this assay, from the lowest: compound 3; then compounds 4, 2 and 1 (each within the scatter of the next).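

In this assay, among these compounds, the exchange of methyl for fluoro on an aromatic carbon, para to a large group, gives a 1.6-fold lower number from compound 1 to compound 4 (0.20 log units; within the scatter), the first step here in which the compounds differ in only one place. At this position, one heavy atom of carbon gives way to one of fluorine, with no hydrogen-bond donor, hydrogen-bond acceptor or net charge entering or leaving, and the number stays within the scatter, so compound 1 and compound 4 cannot be ordered and this swap has no effect that can be told apart from repeat variation. No measurement at hand bears on why the step is this size.

As far as these compounds go, whether a chloro, a trifluoromethyl or an amino group on this same aromatic carbon would also stay within the scatter remains open, as a single step says nothing about the other groups this position might carry. Also open, from the compounds shown here alone, is whether fluoro in place of methyl would give a step of similar size on a different aromatic carbon, or in a compound with another core.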